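This account rests on a few compounds, and the source may have more. Where it says the series, first, only, none or still open, it means among the compounds named here.

Compound 1 `Clc1ccc(C2CC(c3ccc(N4CCCCC4)cc3)=NN2c2nc(-c3ccccc3)cs2)cc1` sets the reference point: in a functional assay on MCF7 cells (Homo sapiens) for antiproliferative activity, read by MTT assay, with a stated time of 72 h (on this read-out higher numbers stand for weaker inhibition and lower numbers for stronger inhibition), compound 1 gives 28400 nM. Compound 2 `Clc1ccc(-c2csc(N3N=C(c4ccc(N5CCCCC5)cc4)CC3c3ccc(Cl)cc3)n2)cc1` carries chloro in place of hydrogen on an aromatic carbon, and in this assay compound 2 reaches only the limit > 100000 nM. Compound 3 `Clc1ccc(C2CC(c3ccc(N4CCCCC4)cc3)=NN2c2nc(-c3ccc(Br)cc3)cs2)cc1` carries bromo at that same aromatic carbon; in this assay compound 3 likewise reaches only the limit > 100000 nM. The two substituted analogues therefore share (the limit of > 100000 nM in this assay, at which 2 of the 3 values shown sit), and compound 3 stands at the weak end of the series. The measured steps read an at least 3.5-fold higher number from compound 1 to compound 2 (0.54 log units; beyond the scatter) and an at least 3.5-fold higher number from compound 1 to compound 3 (0.54 log units; beyond the scatter), while a step that the two limits leave unreadable from compound 2 to compound 3 because both values sit at the limit.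

Compound 4 `N#Cc1ccc(-c2csc(N3N=C(c4ccc(N5CCCCC5)cc4)CC3c3ccc(Cl)cc3)n2)cc1` differs from compound 3 in one place: cyano in place of bromo on an aromatic carbon. Going by the values given here, the steps that bear on this change are the two from compound 1, each showing that a substituent in this position weakened inhibition by an at least modest amount, and the unreadable step between compound 2 and compound 3. Nothing measured separates cyano from the halogens here. Compound 4 is therefore expected to remain close to compound 3, with an estimated step of an at least 1.1-fold lower number from compound 3 to compound 4 (0.04 log units; that floor lies within the scatter). The estimate for compound 4 in this assay is 90000 nM, within a range from 20000 nM to 400000 nM.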

Compound 4, half-maximal inhibitory concentration: 9760 nM
Estimate against measurement, compound 4: 9.2-fold (0.96 log units) above, outside the stated range (below it).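

In this assay, the change from 4-bromophenyl to 4-cyanophenyl is far from neutral: it gives an at least 10-fold lower number from compound 3 to compound 4 (1.01 log units; beyond the scatter), and putting cyano in place of chloro gives an at least 10-fold lower number from compound 2 to compound 4 (1.01 log units; beyond the scatter). A substituent at this aromatic carbon therefore does not weaken inhibition merely by being there, since cyano also improves on hydrogen, with a 2.9-fold lower number from compound 1 to compound 4 (0.46 log units; beyond the scatter), whereas chloro and bromo both moved the number the other way. Among these four compounds, the outcome at this position depends on which group sits there, with the unsubstituted compound 1 lying between compound 4 and the two halogen compounds.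

The step between compound 2 and compound 3 cannot be read, because both compounds stop at a limit of the assay: the limit of > 100000 nM in this assay, at which 2 of the 4 values shown sit. The compounds shown leave open whether the gain belongs to the nitrile alone or extends to other groups at this carbon, such as a carboxylic acid, an amine or a methoxy group, and whether any of these would bring the number lower than compound 4 does.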